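This account rests on a few compounds, and the source may have more. Where it says the series, first, only, none or still open, it means among the compounds named here.

Compound 1 `Cc1nnc(CN(C)C)n1-c1ccc(Cl)cc1C(=O)c1ccccc1` gives 2.2 mg/kg in a functional assay on the whole organism (strain CF-1) with Mus musculus as the target; a lower number here means that less compound is needed, a higher number that more compound is needed for the effect.
Compound 2 `Cc1nnc(CN2CCCC2)n1-c1ccc(Cl)cc1C(=O)c1ccccc1` gives 1.3 mg/kg in this assay.

Among the compounds with values here, compound 2 holds the lowest of the two numbers measured so far, and its only neighbour is compound 1, which stands apart from it by a step that lies within the scatter: a 1.7-fold lower number from compound 1 to compound 2 (0.23 log units; within the scatter). The two numbers therefore cannot be ranked against each other.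

The unmeasured compound 3 `CNCc1nnc(C)n1-c1ccc(Cl)cc1C(=O)c1ccccc1` differs from compound 2 in one place: methylamino in place of pyrrolidin-1-yl on a saturated chain carbon bound to an aromatic carbon. Within the data shown here, only one measured step concerns the same position, and it was small: a 1.7-fold lower number from compound 1 to compound 2 (0.23 log units; within the scatter). That step also exchanged one amine for another on the saturated chain carbon bound to the aromatic carbon, and the number moved within the scatter. The change to methylamino is of the same kind, so for compound 3 no step beyond the scatter is expected in this assay, in either direction; the expected step is a 1.5-fold higher number from compound 2 to compound 3 (0.19 log units; within the scatter). Compound 3 is accordingly estimated at 2 mg/kg, with a range from 0.8 mg/kg to 5 mg/kg.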

Compound 3, dose for half-maximal effect: 0.8 mg/kg
Compound 3: middle estimate off by 2.5-fold (0.40 log units), on the high side; low and high end bracket the measured number.
By their numbers in this assay, from the lowest: compounds 3, 2 and 1 (each within the scatter of the next, the first and the last beyond it).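

In this assay compound 3 is the only one of the three whose amine keeps a hydrogen on its nitrogen, and replacing pyrrolidin-1-yl with methylamino on the saturated chain carbon bound to an aromatic carbon leaves the number within the scatter (a 1.6-fold lower number from compound 2 to compound 3 (0.21 log units; within the scatter)), so compound 2 and compound 3 cannot be ranked. Within the data shown here, compound 3 also supplies the only step at this position that clears the scatter (a 2.8-fold lower number from compound 1 to compound 3 (0.44 log units; beyond the scatter)): hydrogen in place of methyl on the amine nitrogen lowers the dose needed, but the step is modest and rests on this one pair. Nothing available explains either step.

The compounds shown leave open whether the lower number seen on going from dimethylamino to methylamino continues to a primary amine, with two hydrogens on the nitrogen, or holds for a longer substituent such as ethylamino. They also leave open whether a six-membered ring amine such as piperidine or morpholine would stay within the scatter of pyrrolidin-1-yl at the same place.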